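Removing the pyridine methyl from compound 1

This account rests on a few compounds, and the source may have more. Where it says the series, first, only, none or still open, it means among the compounds named here.

Compound 1 `Cc1ccc([C@@H](C)Oc2cc3onc(CCC(=O)O)c3cc2Cl)nc1` holds the lowest number of the two measured in an assay on HEK293 cells for inhibition of kynurenine 3-monooxygenase (Homo sapiens), read by LC-MS, with a stated time of 20 h (a lower number here means a stronger inhibitor, a higher number a weaker inhibitor), where compound 1 gives 1.59 nM. Compound 2 `C[C@@H](Oc1cc2oc(=O)n(CCC(=O)O)c2cc1Cl)c1cccnn1`, built on a different core, gives 631 nM in this assay, a far weaker result. Compound 3 `C[C@@H](Oc1cc2onc(CCC(=O)O)c2cc1Cl)c1ccccn1` keeps the core of compound 1 and differs only by hydrogen in place of methyl on an aromatic carbon. Among the compounds with values here, no measured pair isolates this change, so its size in this assay is open; a modest weakening is expected. Compound 3 is estimated at 4 nM (range 1.5 nM to 12 nM), an expected step of a 2.5-fold higher number from compound 1 to compound 3 (0.40 log units; beyond the scatter).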

Compound 3, half-maximal inhibitory concentration in the kynurenine 3-monooxygenase assay: 3.16 nM
Compound 3: the middle estimate sits 1.3-fold (0.10 log units) above what was measured; low and high end bracket the measured number.
By their numbers in the kynurenine 3-monooxygenase assay, from the lowest: compounds 1 and 3 (each within the scatter of the next); then compound 2.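

In the kynurenine 3-monooxygenase assay the exchange of 5-methylpyridin-2-yl for pyridin-2-yl gives a 2.0-fold higher number from compound 1 to compound 3 (0.30 log units; within the scatter) and so leaves inhibition unresolved between the two compounds; this methyl is not required for a nanomolar result on this core. The same position does register in a physicochemical assay for lipophilicity, read by HPLC, at pH 7.4 (on this read-out lower numbers stand for lower lipophilicity and higher numbers for higher lipophilicity), as well. In the physicochemical assay compound 1 gives 2.42 while compound 3 gives 1.99 and the step reads a number 0.43 log units lower from compound 1 to compound 3 (beyond the scatter) in this pair.

As far as these compounds go, whether a larger group here, such as ethyl, methoxy or an amine, keeps inhibition remains open. So does whether the methyl behaves alike on other cores.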